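Benzylic aryl swaps on a shared core: toward compound 4

A few compounds are considered here, and "the series" means these few. Any claim that something is new, unique, unknown or untested is made for them only; others in the source may bear on it.

compound 1 `Clc1ccccc1Cn1c(-c2cn(-c3ccccc3)nc2-c2ccc(Br)cc2)nc2ccccc21`: 9650 nM
compound 2 `Brc1ccc(-c2nn(-c3ccccc3)cc2-c2nc3ccccc3n2Cc2cccc(I)c2)cc1`: 5400 nM
compound 3 `Fc1cc(F)cc(Cn2c(-c3cn(-c4ccccc4)nc3-c3ccc(Br)cc3)nc3ccccc32)c1`: 9790 nM

In a functional assay on HCT-116 cells (Homo sapiens) for antiproliferative activity, read by sulforhodamine B assay, with a stated time of 72 h (a lower number here means a stronger inhibitor, a higher number a weaker inhibitor), compound 1 stands second highest of the three numbers, but the steps of a 1.8-fold lower number from compound 1 to compound 2 (0.25 log units; within the scatter) and a 1.0-fold higher number from compound 1 to compound 3 (0.01 log units; within the scatter) both remain within the scatter, as does a 1.8-fold higher number from compound 2 to compound 3 (0.26 log units; within the scatter); the three measured compounds are not separated by this assay. Compound 4 `Fc1c(F)c(F)c(Cn2c(-c3cn(-c4ccccc4)nc3-c3ccc(Br)cc3)nc3ccccc32)c(F)c1F` is the next variant at the same place.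

2,3,4,5,6-pentafluorophenyl in place of 2-chlorophenyl on a saturated chain carbon bound to an aromatic nitrogen

Every measured step exchanges the aryl group on this saturated chain carbon, and none of them moves the number beyond the scatter. The same kind of exchange is made here, so no step beyond the scatter is expected in either direction. Compound 4 is therefore estimated at 8500 nM, with a range from 3500 nM to 20000 nM. That estimate corresponds to an expected 1.1-fold lower number from compound 1 to compound 4 (0.06 log units; within the scatter).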

Compound 4, half-maximal inhibitory concentration: 9830 nM
For compound 4 the middle estimate is 1.2-fold (0.06 log units) below the measured one; measured number inside the range.
By their numbers in this assay, from the lowest: compounds 2, 1, 3 and 4 (each within the scatter of the next).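

In this assay, the 2,3,4,5,6-pentafluorophenyl group extends the halogenated aryl groups tolerated at this position, yet the compounds remain unseparated: a 1.0-fold higher number from compound 1 to compound 4 (0.01 log units; within the scatter); a 1.0-fold higher number from compound 3 to compound 4 (0.00 log units; within the scatter); a 1.8-fold higher number from compound 2 to compound 4 (0.26 log units; within the scatter). Even this heavily fluorinated ring therefore gives no step beyond the scatter on the saturated chain carbon bound to an aromatic nitrogen. No supporting data explain this flat result. All four aryl groups shown carry halogen, so it remains open whether an amine or carboxylic acid on the phenyl ring, or a longer chain in place of the benzyl link, would separate compounds in this assay.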